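A Smaller Heteroaromatic Ether Replaces the Quinazolinyl Group

A few compounds are considered here, and "the series" means these few. Any claim that something is new, unique, unknown or untested is made for them only; others in the source may bear on it.

Compound 1 `CC(C)[C@H](NC(=O)COc1cccc2ccccc12)C(=O)N[C@@H](CC(=O)O)C(=O)CSc1nnc(-c2ccccc2)o1` and compound 2 `CC(C)[C@H](NC(=O)COc1cccc2ccccc12)C(=O)N[C@@H](CC(=O)O)C(=O)COc1ncnc2ccccc12` share one core and differ only in the group on a saturated chain carbon bound to a carbonyl carbon. In a functional assay on Jurkat cells (Homo sapiens) for inhibition (a lower number here means a stronger inhibitor, a higher number a weaker inhibitor), compound 1 gives 150000 nM. For compound 2 in this assay there is only a limit, > 200000 nM, and no number. The measured step is an at least 1.3-fold higher number from compound 1 to compound 2 (0.12 log units; that floor lies within the scatter), and compound 2 therefore stands at the weak end of what is shown, at the limit of the limit of > 200000 nM in this assay, at which 1 of the 2 values shown sits. Compound 3 `CC(C)[C@H](NC(=O)COc1cccc2ccccc12)C(=O)N[C@@H](CC(=O)O)C(=O)COc1[nH]cnc2nncc1-2` remains unmeasured; it differs from compound 2 by a group of 9 heavy atoms (5 carbon, 4 nitrogen; one five-membered aromatic ring with 2 hetero atoms, one six-membered aromatic ring with 2 hetero atoms) in place of a group of 10 heavy atoms (8 carbon, 2 nitrogen; one six-membered aromatic ring of carbon only, one six-membered aromatic ring with 2 hetero atoms), on an oxygen on a saturated carbon. For the measured compounds named here, only the step from compound 1 to compound 2 bears on this, and it left compound 2 at a limit, so its size cannot be fully told. Compound 3 is therefore expected to give 200000 nM, within 80000 nM to 500000 nM. The expected step is a number no higher from compound 2 to compound 3 (the limit leaves the size open), with no change beyond the scatter.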

Compound 3, half-maximal inhibitory concentration: 161000 nM
Compound 3: middle estimate off by 1.2-fold (0.09 log units), on the high side; measured number inside the range.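

For the compounds shown here, with a number now in place of a limit, three quite different groups on this position can be compared for the first time in this assay. The step is a 1.1-fold higher number from compound 1 to compound 3 (0.03 log units; within the scatter), so the group of compound 3 and the (5-phenyl-1,3,4-oxadiazol-2-yl)sulfanyl group of compound 1 cannot be told apart here, even though they differ in their rings and in the atom bound to the chain carbon. Exchanging quinazolin-4-yl on the oxygen gives an at least 1.2-fold lower number from compound 2 to compound 3 (0.09 log units; that floor lies within the scatter), and the true size of that step stays unknown, since compound 2 has only a limit: the limit of > 200000 nM in this assay, at which 1 of the 3 values shown sits.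

The compounds shown leave open whether any group on this saturated chain carbon bound to a carbonyl carbon can move the number beyond the scatter. A simple phenoxy group or an amine in this place would test that.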